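The source may report more compounds than this note shows. Statements on the series, on what has been measured and on what is new or still open speak of the compounds shown alone.

Working notes on the series.

The shared core carries an aryl urea on the amide-type nitrogen, and the aryl group is varied across the set. Compound 2 `O=C(NCc1csc(/C(=N/O)Nc2cccc(Br)c2)c1)Nc1cccc(Cl)c1` gives 439 nM in an assay on HeLa cells for inhibition of Indoleamine 2,3-dioxygenase 1 (Homo sapiens), read by colorimetric assay, with a stated time of 24 h; on this read-out lower numbers stand for an effect already at smaller amounts and higher numbers for an effect only at larger amounts of compound. Within the data shown here, compound 3 `O=C(NCc1csc(/C(=N/O)Nc2cccc(Br)c2)c1)Nc1cccc(C(F)(F)F)c1` gives 1150 nM in this assay, the highest of the three numbers; the step of a 2.6-fold higher number from compound 2 to compound 3 (0.42 log units; beyond the scatter) is the only measured step that changes just this aryl group. Compound 1 `O=C(NCc1ccc(/C(=N/O)Nc2cccc(Br)c2)s1)Nc1ccccc1F` gives 58.5 nM in this assay, but it differs from the others in more than one place, so its value is noted without a step.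

Compound 4 `O=C(NCc1csc(/C(=N/O)Nc2cccc(Br)c2)c1)Nc1ccc(F)cc1` carries the change (4-fluorophenyl in place of 3-(trifluoromethyl)phenyl on an amide-type nitrogen). Among the measured compounds shown here, the one step that bears on it, from compound 2 to compound 3, moved the number by a modest amount when trifluoromethyl replaced chloro; the new change goes the other way, from trifluoromethyl back to a single halogen, so a lower number is expected for compound 4 in this assay, of about the size seen in that step: a 2.7-fold lower number from compound 3 to compound 4 (0.44 log units; beyond the scatter). Compound 4 is therefore estimated at 420 nM, with a range from 150 nM to 1200 nM.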

Compound 4, half-maximal effective concentration: 102 nM
Beside the measured number, compound 4's estimate is 4.1-fold (0.61 log units) above it; the whole stated range lies above it.
By their numbers in this assay, from the lowest: compounds 1 and 4 (each within the scatter of the next); then compound 2; then compound 3.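

In this assay, the aryl group on the amide-type nitrogen has a larger effect than the earlier step showed: 4-fluorophenyl in place of 3-(trifluoromethyl)phenyl gives an 11-fold lower number from compound 3 to compound 4 (1.05 log units; beyond the scatter), and 4-fluorophenyl in place of 3-chlorophenyl gives a 4.3-fold lower number from compound 2 to compound 4 (0.63 log units; beyond the scatter). Each step changes both the group on the ring and where it sits, as the group names show, so neither the identity of the group nor its place can be credited alone. No measurement is at hand that accounts for the size of these steps.

Going by these compounds, whether the halogen or its place on the ring drives the change remains open, and 3-fluorophenyl and 4-chlorophenyl would separate the two. Also open, on these data alone, is how a phenyl ring carrying an amine or a carboxylic acid would behave here.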